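This account rests on a few compounds, and the source may have more. Where it says the series, first, only, none or still open, it means among the compounds named here.

Measured so far:
compound 1 `Cc1ccc(N2C(=O)CSC2c2sc(Cc3ccc(Cl)cc3)nc2C)cc1` — 81.3%
compound 2 `Cc1nc(-c2ccc(Cl)cc2)sc1C1SCC(=O)N1c1ccc(F)cc1` — 67.6%
compound 3 `Cc1nc(Cc2ccc(Cl)cc2)sc1C1SCC(=O)N1c1ccccc1` — "not active" (no number reported)

In a functional assay on the whole organism (strain Wistar albino) for inhibition, with Rattus norvegicus as the target, read by paw edema, with stated times of 1 h and 4 h, at a dose of 40 mg/kg by the oral route (on this read-out higher numbers stand for more inhibition at the one dose given (going by the name of the read-out) and lower numbers for less inhibition), compound 2 gives the lower of the two numbers recorded, with compound 1 standing higher by a margin beyond the usual scatter, while compound 3 is reported without a number. Compound 4 `Cc1ccc(N2C(=O)CSC2c2sc(-c3ccc(Cl)cc3)nc2C)cc1` is not yet measured; it differs from compound 2 by methyl in place of fluoro on an aromatic carbon. Among the measured compounds, the methyl-bearing ring of compound 4 is also found in compound 1, which gives 81.3%, whereas compound 3, with no group on that ring, is reported as not active. On this footing the step of a number 7.4 percentage points higher from compound 2 to compound 4 (within the scatter) is expected to be small and upward, possibly not beyond the scatter. Compound 4 is therefore estimated at 75%, within a range from 60% to 88%.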

Compound 4, a percentage reported as inhibition, in the whole organism at one dose (the size of the read-out at that dose, not a potency): 63.9%
Beside the measured number, compound 4's estimate is 11.1 percentage points above it; measured number inside the range.
By their numbers in this assay, from the lowest: compounds 4 and 2 (each within the scatter of the next); then compound 1.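

In this assay, methyl in place of fluoro, 4-fluorophenyl to 4-methylphenyl, gives a number 3.7 percentage points lower from compound 2 to compound 4 (within the scatter), so at this position the two groups cannot be told apart. A change elsewhere in the molecule, 4-chlorophenyl in place of 4-chlorobenzyl, gives a number 17.4 percentage points lower from compound 1 to compound 4 (beyond the scatter), which is the larger step of the two. Nothing available explains either step.

Going by these compounds, it remains open whether a different group at this position, such as an amine or a carboxylic acid, would move the number. On these data alone, it is also open whether the step from 4-chlorobenzyl to 4-chlorophenyl would be the same size with fluoro on the other ring.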